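A few compounds are considered here, and "the series" means these few. Any claim that something is new, unique, unknown or untested is made for them only; others in the source may bear on it.

Compound 1, `Oc1cccc(-c2cc(-c3cccc(O)c3)nc(-c3ccccc3O)c2)c1`: in an ADME assay on HEK293 cells (Homo sapiens) for cytotoxicity, read by CCK-8 assay, with a stated time of 4 days (a higher number here means a weaker inhibitor, a lower number a stronger inhibitor), compound 1 gives > 50000 nM, which is a limit of the assay and not a number.
Compound 2, `Oc1ccc(-c2cc(-c3cccc(O)c3)cc(-c3cccc(O)c3)n2)cc1`: in this assay compound 2 gives 1560 nM.
Compound 3, `Oc1ccc(-c2cc(-c3cccc(O)c3)cc(-c3ccccc3O)n2)cc1`: in this assay compound 3 gives > 50000 nM, again a limit and not a number.

As far as these compounds go, compound 1 thus stands at the limit, where (the limit of > 50000 nM in this assay, at which 2 of the 3 values shown sit), so its exact position among the three is unknown. The unmeasured compound 4, `Oc1ccc(-c2cc(-c3cccc(O)c3)nc(-c3ccccc3O)c2)cc1`, differs from compound 1 by 4-hydroxyphenyl in place of 3-hydroxyphenyl on an aromatic carbon.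

Within the data shown here, two measured steps bear on this. The same exchange, 4-hydroxyphenyl in place of 3-hydroxyphenyl, gives a step that the two limits leave unreadable from compound 1 to compound 3, because both ends sit at a limit. Among the measured compounds shown here, the reverse-type exchange gives an at least 32-fold higher number from compound 2 to compound 3 (1.50 log units; beyond the scatter), showing that the compound keeping the 2-hydroxyphenyl group stays at the limit while the one with three hydroxyphenyl groups on other positions reads a number. Compound 4 keeps the 2-hydroxyphenyl group, as compound 3 does, so no step beyond the scatter is expected in this assay, and a limit is the most likely outcome.

Compound 4 is therefore estimated at 50000 nM in this assay, with a range from 10000 nM to 200000 nM. The expected step is a number no higher from compound 1 to compound 4 (the limit leaves the size open).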

Compound 4, half-maximal inhibitory concentration: 7420 nM
Compound 4: the middle estimate sits 6.7-fold (0.83 log units) above what was measured; the whole stated range lies above it.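

In this assay, among these compounds, the only change at the aromatic carbon opposite the ring nitrogen is 4-hydroxyphenyl in place of 3-hydroxyphenyl, and it gives an at least 6.7-fold lower number from compound 1 to compound 4 (0.82 log units; beyond the scatter). The atoms are the same in both compounds, so moving one hydroxyl around its phenyl ring at this place is enough to shift the read-out beyond the scatter, and compound 4 shows that keeping a 2-hydroxyphenyl group does not by itself hold a compound at the limit. The true size of the step remains unknown, because compound 1 gives only a limit and not a number: the limit of > 50000 nM in this assay, at which 2 of the 4 values shown sit.

The compounds shown leave open whether a hydroxyl is needed at this place at all, since none carries a plain phenyl there, or a phenyl bearing an amine or a carboxylic acid. Also open, as far as these compounds go, is whether the same exchange at this place would have a similar effect on a compound without the 2-hydroxyphenyl group.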